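Replacing 4-aminocyclohexyl with (methoxycarbonyl)methyl in compound 2

The compounds below may be only part of what the source reports. "The series", "measured", "known", "first", "only" and "open" are said of these compounds alone.

Of the compounds shown here, three have been tested in a functional assay on HCT-116 cells (Homo sapiens) for cytotoxicity, read by MTT assay, with a stated time of 72 h; a lower number here means a stronger inhibitor, a higher number a weaker inhibitor. Compound 1 `N[C@H]1CC[C@H](Nc2c(C(=O)NCc3ccc(Oc4ccccc4)cc3)nc(Br)c3cccnc23)CC1` carries no result there, "not determined" (no result reported). Compound 2 `N[C@H]1CC[C@H](Nc2c(C(=O)NCc3ccc(F)cc3)nc(Br)c3cccnc23)CC1` gives 7000 nM in this assay. For compound 3 `C[C@H](NC(=O)c1nc(Br)c2cccnc2c1N[C@H]1CC[C@H](N)CC1)c1ccc(F)cc1` this assay reports only a limit, > 10000 nM. Compound 2 thus holds the only number shown; one further entry is a limit and one has no result.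

Among the compounds with values here, the single measured step is an at least 1.4-fold higher number from compound 2 to compound 3 (0.15 log units; that floor lies within the scatter), methyl in place of hydrogen on a saturated chain carbon bound to an amide-type nitrogen and an aromatic carbon. It sits on a different part of the molecule and does not bear on the change considered here.

Compound 4 `COC(=O)CNc1c(C(=O)NCc2ccc(F)cc2)nc(Br)c2cccnc12` differs from compound 2 by (methoxycarbonyl)methyl in place of 4-aminocyclohexyl on a nitrogen on an aromatic ring. Within the data shown here, no measured step covers this exchange, so the expectation rests on compound 2 alone and stays wide. Since the limit of > 10000 nM in this assay, at which 1 of the 3 values shown sits, shows that one of the three values already sits at the limit, a limit for compound 4 is a real possibility.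

Compound 4 is expected to give about 10000 nM, within a range from 3000 nM to 30000 nM. This estimate means a step of a 1.4-fold higher number from compound 2 to compound 4 (0.15 log units; within the scatter), expected rather than measured.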

Compound 4, half-maximal inhibitory concentration: > 10000 nM
Compound 4 was reported as a limit (the forecaster's own chance of this, stated with the estimate: 45%); the middle value sits exactly at the limit.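

Within the data shown here, compound 4 gives the first reading with a different group at this position, and in this assay its entry is a limit, > 10000 nM, not a number. Exchanging 4-aminocyclohexyl for (methoxycarbonyl)methyl on a nitrogen on an aromatic ring removes the six-membered non-aromatic ring, both defined stereocentres and the hydrogen-bond donor of that group, and gives an at least 1.4-fold higher number from compound 2 to compound 4 (0.15 log units; that floor lies within the scatter), so the true size of the change may lie within the scatter or beyond it. The reading shows only that this exchange yields no measurable number in this assay, and the limit now restricts what the series can show: the limit of > 10000 nM in this assay, at which 2 of the 4 values shown sit.

From the compounds shown here alone, compound 4 changes the ring and its amine at once, so the share of each in the number of compound 2 stays open. A plain cyclohexyl group would test the ring without the amine and an aminoethyl chain the amine without the ring, while a carboxylic acid in place of the methyl ester would test another acyclic group at this position.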